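The source may hold more compounds than are shown below. What is called first, only, known or untested is meant among the compounds shown, and "the series" means these compounds.

Working notes on the series. Compound 3 `CN(C)/N=N/c1ccc(NC(N)=O)cc1` is the reference point for this step. Within the data shown here, in a functional assay on L1210 cells (Mus musculus) for antiproliferative activity (on this read-out lower numbers stand for lower potency and higher numbers for higher potency (the scale is a negative logarithm)), compound 3 gives 3.97, the highest of the three numbers so far. Compound 1 `COC(=O)c1ccc(/N=N/N(C)C)cc1` gives 3.2 in this assay, and compound 2 `CCCCCCCCN(C)/N=N/c1ccc(C(N)=O)cc1` gives 2.84; both stand lower than compound 3 by more than the scatter.

Compound 4 `CN(C)/N=N/c1ccc(C(N)=O)cc1` has not yet been measured. The change from compound 3 to compound 4 is carbamoyl in place of ureido on an aromatic carbon.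

Among the measured compounds shown here, only one measured step touches the same position: a number 0.77 log units higher from compound 1 to compound 3 (beyond the scatter), where ureido replaced methoxycarbonyl. For the measured compounds named here, no measured pair shows carbamoyl in place of ureido directly. Compound 2 carries a carbamoyl group, but it also differs from compound 3 at the other end of the molecule, so its number can only be read as a loose indication that carbamoyl at this position is not associated with a number as high as that of compound 3.

The expectation is therefore that compound 4 falls below compound 3, with the estimated step of a number 0.67 log units lower from compound 3 to compound 4 (beyond the scatter) in this assay. The estimate for compound 4 is 3.3, with a range from 2.8 to 3.8.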

Compound 4, logarithm of the reciprocal of the active concentration, log(1/C) in the L1210 assay: 3.51
Estimate against measurement, compound 4: 0.21 log units below, within the range that was stated.
By their numbers in the L1210 assay, from the lowest: compound 2; then compound 1; then compound 4; then compound 3.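

In the L1210 assay the position can now be read with three groups on the same core: a number 0.46 log units lower from compound 3 to compound 4 (beyond the scatter) and a number 0.31 log units higher from compound 1 to compound 4 (beyond the scatter) place carbamoyl between ureido and methoxycarbonyl, with each step beyond the scatter. Compound 4 also turns compound 2 into a one-place comparison, since with carbamoyl held constant a number 0.67 log units higher from compound 2 to compound 4 (beyond the scatter) gives the size of hydrogen in place of heptyl at the other end of the molecule. In a physicochemical assay for lipophilicity (on this read-out higher numbers stand for higher lipophilicity and lower numbers for lower lipophilicity), compound 3 gives 1.25 and compound 4 gives 1.2, two values within the scatter of each other, so this read-out does not separate the pair that differs in the L1210 assay, and no available evidence bears on the reason for that difference.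

On these data alone, whether an amine or a carboxylic acid on the same aromatic carbon would fit this order remains open. Also open, as far as these compounds go, are whether the heptyl step has a similar size with ureido in place of carbamoyl, and where a chain of intermediate length would stand.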